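The compounds below may be only part of what the source reports. "The series", "measured", "known", "first", "only" and "open" are said of these compounds alone.

Working notes on the series. Within the data shown here, compound 2 `COc1ccc(C(=O)c2cc(OC)c(OC)c(OC)c2)cc1NC(=O)/C=C/c1ccc(C(F)(F)F)cc1` holds the lowest number of the two measured so far: in a functional assay on HeLa cells (Homo sapiens) for cytotoxicity, read by MTT assay, with a stated time of 72 h (a lower number here means a stronger inhibitor, a higher number a weaker inhibitor), compound 2 gives 90 nM. Its nearest neighbour is compound 1 `COc1ccc(C(=O)c2cc(OC)c(OC)c(OC)c2)cc1NC(=O)/C=C/c1cc(OC)c(OC)c(OC)c1`, which in this assay gives 1500 nM. Among the measured compounds shown here, the one step between measured compounds, a 17-fold lower number from compound 1 to compound 2 (1.22 log units; beyond the scatter), replaced the whole aryl on the double-bonded chain carbon and is well beyond the scatter.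

Compound 3 `COc1ccc(C(=O)c2cc(OC)c(OC)c(OC)c2)cc1NC(=O)/C=C/c1ccc(N)cc1` is the next entry, not yet measured. It differs from compound 2 by amino in place of trifluoromethyl on an aromatic carbon. For the measured compounds named here, no measured step alters this aryl substituent alone; the step from compound 1 to compound 2 bears on it only loosely, since there both the ring substitution pattern and the substituent kind changed at once. What it does show is that the group on this ring can move the number strongly. The trifluoromethyl of compound 2 is the only substituent so far paired with the low number, so a shift toward a higher number is expected for compound 3, of moderate size, a 4.4-fold higher number from compound 2 to compound 3 (0.65 log units; beyond the scatter). Compound 3 is accordingly estimated at 400 nM in this assay, with a range from 100 nM to 1600 nM.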

Compound 3, half-maximal inhibitory concentration: 14700 nM
Beside the measured number, compound 3's estimate is 37-fold (1.57 log units) below it; measured number outside the range, above it.
By their numbers in this assay, from the lowest: compound 2; then compound 1; then compound 3.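

In this assay, the change of one substituent on an aromatic carbon, para to a large group, now stands as a step of its own (a 160-fold higher number from compound 2 to compound 3 (2.21 log units; beyond the scatter)), so amino in place of trifluoromethyl moves the number strongly with the rest of compound 2 unchanged, which the earlier step, replacing the whole aryl, could not show. The 4-substituted phenyl alone does not bring the low number: 4-(trifluoromethyl)phenyl in compound 2 stands on the lower side of compound 1, while 4-aminophenyl stands on the higher side (a 9.8-fold higher number from compound 1 to compound 3 (0.99 log units; beyond the scatter)). Nothing available on these compounds explains the size of either step.

Still open, from the compounds shown here alone, is whether the low number belongs to trifluoromethyl alone or would also come with a chlorine, a nitrile or a methoxy on this aromatic carbon. Also open, going by these compounds, is whether an acetamide in place of amino would stay near compound 3 or move toward compound 2, and how trifluoromethyl behaves on another carbon of this ring.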